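The source may hold more compounds than are shown below. What is called first, only, known or untested is meant among the compounds shown, and "the series" means these compounds.

In a functional assay on SK-OV-3 cells (Homo sapiens) for inhibition, read by MTT assay (a lower number here means a stronger inhibitor, a higher number a weaker inhibitor), compound 1 `COc1ccc(/C=C2\c3cc(OC)c(OC)c(OC)c3CC[C@@H]2O)cc1N` gives 740 nM and compound 2 `COc1ccc(/C=C2\c3cc(OC)c(OC)c(OC)c3CC[C@H]2O)cc1N` gives 1870 nM, which makes compound 2 the weaker inhibitor of the two. Within the data shown here, the only measured step, a 2.5-fold higher number from compound 1 to compound 2 (0.40 log units; beyond the scatter), goes with the fact that compounds 1 and 2 differ only in the configuration as drawn. Compound 3 `COc1ccc(/C=C2\c3cc(OC)c(OC)c(OC)c3CC[C@H]2O)cc1C` keeps the configuration of compound 2 but swaps one group: methyl in place of amino on an aromatic carbon. This is methyl in place of amino on an aromatic carbon, ortho to a methoxy group. The measured step between compound 1 and compound 2 touches a different place, so it offers only a rough sense of size and no direction for this swap. No step beyond the scatter can be firmly expected in this assay, and the estimated change, a 1.3-fold higher number from compound 2 to compound 3 (0.13 log units; within the scatter), is uncertain. The expected value for compound 3 is 2500 nM, with an estimated range from 600 nM to 10000 nM.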

Compound 3, half-maximal inhibitory concentration: 1340 nM
Estimate against measurement, compound 3: 1.9-fold (0.27 log units) above; the range from low to high includes it.
By their numbers in this assay, from the lowest: compounds 1, 3 and 2 (each within the scatter of the next, the first and the last beyond it).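

In this assay, putting methyl in place of amino on the 3-amino-4-methoxyphenyl group of compound 2 gives a 1.4-fold lower number from compound 2 to compound 3 (0.14 log units; within the scatter). Among these compounds, this is the first reading of this position, and it shows that, in this configuration, a group counted with no hydrogen-bond donor or acceptor can stand where amino stood without a step beyond the scatter. None of the information available gives a reason for this result.

From the compounds shown here alone, it remains open whether the same swap would behave the same way in the configuration of compound 1, since only the configuration of compound 2 carries methyl here. Going by these compounds, it is also open how this position would respond to a different group, such as a hydroxyl, a chlorine atom or a longer chain like ethyl.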